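Swapping the sulfonyl aryl group in compound 3

The source may report more compounds than this note shows. Statements on the series, on what has been measured and on what is new or still open speak of the compounds shown alone.

Measured so far:
Compound 1 `O=S(=O)(NCCCCNCc1ccc(Br)cc1)c1cc(C(F)(F)F)cc(C(F)(F)F)c1`: 2100 nM
Compound 2 `O=S(=O)(NCCCNCc1ccc(Cl)c(Cl)c1)c1cc(C(F)(F)F)cc(C(F)(F)F)c1`: 2700 nM
Compound 3 `O=S(=O)(NCCCCCCNCc1ccc(Br)cc1)c1ccc2c(c1)OCC2`: 13000 nM

These numbers come from a functional assay on MIA PaCa-2 cells (Homo sapiens) for inhibition, read by MTT assay, with a stated time of 72 h; a higher number here means a weaker inhibitor of growth, a lower number a stronger inhibitor of growth. Compound 3 stands highest of the three; compound 2 is its nearest neighbour and compound 1 the furthest, both beyond the scatter. Compound 4 `Cc1ccc(S(=O)(=O)NCCCCCCNCc2ccc(Br)cc2)cc1` differs from compound 3 in one place: a group of 7 heavy atoms (7 carbon; one six-membered aromatic ring of carbon only) in place of a group of 9 heavy atoms (8 carbon, 1 oxygen; one five-membered non-aromatic ring with 1 hetero atom, one six-membered aromatic ring of carbon only), on a sulfonyl sulfur. Among the compounds with values here, the only measured step, a 1.3-fold higher number from compound 1 to compound 2 (0.11 log units; within the scatter), changes the ((4-bromobenzyl)amino)methyl end, not the group on the sulfonyl sulfur, so no measured pair isolates the change at hand. With nothing directly comparable, the expectation for compound 4 is a number near that of compound 3, with a wide range. Compound 4 is therefore estimated at 15000 nM (5000 nM to 45000 nM), an expected step of a 1.2-fold higher number from compound 3 to compound 4 (0.06 log units; within the scatter).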

Compound 4, concentration for 50% growth inhibition: 12300 nM
Beside the measured number, compound 4's estimate is 1.2-fold (0.09 log units) above it; low and high end bracket the measured number.
By their numbers in this assay, from the lowest: compounds 1 and 2 (each within the scatter of the next); then compounds 4 and 3 (each within the scatter of the next).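

On the sulfonyl sulfur, 4-methylphenyl in place of the group carrying a five-membered non-aromatic ring gives a 1.1-fold lower number from compound 3 to compound 4 (0.02 log units; within the scatter) in this assay on the otherwise shared structure. Within the data shown here, this is the first single change read at this position, and losing that ring and its oxygen leaves the number within the scatter. No evidence is available to explain this result.

On these data alone, compounds 1 and 2 differ from compound 3 in more than one place, so the part the sulfonyl group plays in their lower numbers stays open. As far as these compounds go, whether any group on this sulfur moves the number, such as a pyridine ring or a phenyl ring bearing a carboxylic acid, also stays open.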